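Fluoro to chloro on the aromatic carbon: cytotoxicity outlook

The source may hold more compounds than are shown below. What is called first, only, known or untested is meant among the compounds shown, and "the series" means these compounds.

Compound 2 `COc1ccccc1S(=O)(=O)/C=C/c1ncccc1F` sits level with compound 1 `COc1ccccc1S(=O)(=O)/C=C/c1ccccn1` in an ADME assay on BV-2 cells (Mus musculus) for cytotoxicity, with a stated time of 24 h, tested at 50 uM (a lower number here means a stronger effect, a higher number a weaker effect of the compound at the concentration tested), the two within the scatter of each other; there compound 2 gives 99.2%, and compound 1 gives 100%. Among the compounds with values here, the single measured step, a number 0.8 percentage points lower from compound 1 to compound 2 (within the scatter), is the only one bearing on the next change and was flat. Compound 3 `COc1ccccc1S(=O)(=O)/C=C/c1ncccc1Cl` differs from compound 2 by chloro in place of fluoro on an aromatic carbon. No movement beyond the scatter is therefore expected in this assay; the expected step is a number 1.2 percentage points lower from compound 2 to compound 3 (within the scatter). For compound 3 the estimate is 98%, with a range of 88% to 104%.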

Compound 3, a percentage reported as activity, at one concentration (the size of the read-out at that concentration, not a potency): 100%
Compound 3: the middle estimate sits 2 percentage points below what was measured; measured number inside the range.
By their numbers in this assay, from the lowest: compounds 2, 1 and 3 (each within the scatter of the next).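

In this assay the aromatic carbon two atoms from the ring nitrogen tolerates chloro as it does fluoro, with a number 0.8 percentage points higher from compound 2 to compound 3 (within the scatter). Set against hydrogen at the same carbon, chloro gives no change at the digits printed from compound 1 to compound 3 (within the scatter), so hydrogen, fluoro and chloro all read alike here. Nothing available explains this flat result. Open, from the compounds shown here alone, is whether an amine or a carboxylic acid on this carbon would also stay level in this assay. Also open, going by these compounds, is whether changes elsewhere on the shared core would move the read-out.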